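A Second Sulfonyl Swap at the Detection Limit

A few compounds are considered here, and "the series" means these few. Any claim that something is new, unique, unknown or untested is made for them only; others in the source may bear on it.

compound 1 `O=S(=O)(Nc1ccc2oc(-c3ccccc3)nc2c1)c1ccc(O)cc1` — > 63000 nM
compound 2 `CCc1ccc(S(=O)(=O)Nc2ccc3oc(-c4ccccc4)nc3c2)cc1` — > 63000 nM

In an assay on isolated protein for inhibition of malate dehydrogenase, mitochondrial (Sus scrofa), with stated times of 45 min and 30 min (on this read-out higher numbers stand for weaker inhibition and lower numbers for stronger inhibition), compound 1 reaches only the limit of the measurement, > 63000 nM. Compound 2 likewise stops at the limit, > 63000 nM. The step that the two limits leave unreadable from compound 1 to compound 2 therefore cannot be read, because both values sit at the limit of > 63000 nM in this assay, at which 2 of the 2 values shown sit. Compound 3 `COc1ccccc1S(=O)(=O)Nc1ccc2oc(-c3ccccc3)nc2c1` carries the change (2-methoxyphenyl in place of 4-ethylphenyl on a sulfonyl sulfur). Among the compounds with values here, no measured step shows what this swap does, and compound 2 itself gives no number to move from. The step expected a step that the limit leaves unreadable from compound 2 to compound 3 is therefore nothing that could be told apart from the scatter. The estimate for compound 3 in this assay is 80000 nM, between 20000 nM and 300000 nM, most likely again only a limit.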

Compound 3, half-maximal inhibitory concentration: > 63000 nM
Compound 3: only a limit was reported (the forecaster's own chance of this, stated with the estimate: 85%); the middle value is on the limit's open side.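

Within the data shown here, no step among compound 1, compound 2 and compound 3 can be read, because each result is a limit and not a number: the limit of > 63000 nM in this assay, at which 3 of the 3 values shown sit. The compounds shown leave open whether swapping the group on the sulfonyl sulfur changes inhibition at all.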